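The source may hold more compounds than are shown below. What is called first, only, known or untested is meant among the compounds shown, and "the series" means these compounds.

Among the compounds with values here, in a physicochemical assay for lipophilicity, using the shake flask method, in phosphate buffer, measured as octanol-water partition, with a stated time of 24 h, at pH 7.4, tested at 100 uM (a lower number here means a more polar compound, a higher number a more lipophilic compound), compound 1 `COc1cc(C)c(-c2cccc(COc3ccc(S(=O)(=O)CC(=O)O)cc3)c2)c(C)c1` gives 2.45, and this is the only number available for the series. Compound 2 `COc1cc(C)c(-c2cccc(COc3ccc4c(c3)S(=O)(=O)CC4CC(=O)O)c2)c(C)c1` has no such number, its entry reading "not determined" (no result reported). Compound 3 `COc1cc(C)c(-c2cccc(COc3ccc4c(c3)C(=O)CC4CC(=O)O)c2)c(C)c1` likewise has no number, with an entry of "not determined" (no result reported). Within the data shown here, compound 1 therefore cannot be ranked against either of them, and no measured pair shows how much a single structural change moves the reading.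

Compound 4 `Cc1cc(OCC(C)C)cc(C)c1-c1cccc(COc2ccc(S(=O)(=O)CC(=O)O)cc2)c1` departs from compound 1 in one place: isopropyl in place of hydrogen on a saturated chain carbon bound to an oxygen on an aromatic ring. This places isopropyl in place of hydrogen on a saturated chain carbon bound to an oxygen on an aromatic ring, so that methoxy becomes isobutoxy. The rest of the structure stays the same, and the new group carries no net charge and no hydrogen-bond donors or acceptors.

Among the measured compounds shown here, with no measured step to lean on, the expectation rests on that structural change and on compound 1 at 2.45 as its base. A clear upward move in this assay is expected, larger than the usual scatter. The estimated change is a number 0.95 log units higher from compound 1 to compound 4 (beyond the scatter). For compound 4 the estimated value is 3.4, with an expected range from 2.9 to 3.9.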

Compound 4, distribution coefficient: 3.94
Compound 4: the middle estimate sits 0.54 log units below what was measured; the measured number lies above the stated range.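

In this assay, within the data shown here, the reading is a number 1.49 log units higher from compound 1 to compound 4 (beyond the scatter) and this is the first measured step, so this position, a saturated chain carbon bound to an oxygen on an aromatic ring, is now known to respond strongly to a single change. The group that enters is isopropyl, with 3 heavy atoms, all carbon, no ring and no net charge, and it turns methoxy into isobutoxy while the rest of compound 1 stays the same, so the whole step belongs to this one place. Nothing available on these compounds accounts for the size of the step.

A single step cannot show how the reading follows the chain, for instance whether ethyl in place of hydrogen at this place would give only part of the move, whether a longer chain would extend it, or whether an amine or a hydroxyl group here would carry it the other way. From the compounds shown here alone, whether isobutoxy moves the reading by a similar amount on the cores of compound 2 and compound 3 also stays open, since those two compounds offer no number to start from.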